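This account rests on a few compounds, and the source may have more. Where it says the series, first, only, none or still open, it means among the compounds named here.

Compound 1, `CC(C)CC[C@H](O)CCCCCCCCC[C@@H]1N[C@@H](CO)[C@@H]1O`: in a functional assay on HT529 cells (Homo sapiens) for cytotoxicity (a lower number here means a stronger inhibitor, a higher number a weaker inhibitor), compound 1 gives > 2 ug/mL.
Compound 2, `CCCCCCCCCCCCCC[C@@H]1N[C@H](CO)[C@H]1O`: in this assay compound 2 gives 0.79 ug/mL.

The value recorded for compound 1 is a limit of the assay, not a number, as shown by the limit of > 2 ug/mL in this assay, at which 1 of the 2 values shown sits. Among the compounds with values here, compound 2 thus stands at the only number recorded in this assay.

Compound 3, `CCCCCCCCCCCCCC[C@@H]1N[C@H](CO)[C@@H]1O`, is still to be measured. Its difference from compound 2 is the two compounds have the same atoms and bonds and differ only in configuration as drawn: 1 of 3 stereo elements differ; a stereocentre at a saturated ring carbon is drawn S in compound 2 and R in compound 3. Within the data shown here, no measured pair shows the effect of such a change, so the expected step of a 1.9-fold higher number from compound 2 to compound 3 (0.28 log units; within the scatter) is a modest weakening. Compound 3 is estimated at 1.5 ug/mL, between 0.5 ug/mL and 5 ug/mL.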

Compound 3, half-maximal inhibitory concentration: > 2 ug/mL
Compound 3: no number, only a limit; the forecaster's own chance of this, stated with the estimate: 30%; middle value at least 1.3-fold (0.12 log units) from the limit.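

Inverting this single saturated ring carbon gives an at least 2.5-fold higher number from compound 2 to compound 3 (0.40 log units; beyond the scatter), the first step in the series and one beyond the scatter. Compound 3 has a limit, not a number, in this assay: the limit of > 2 ug/mL in this assay, at which 2 of the 3 values shown sit. The weakening can be put down to configuration alone, because nothing else separates the pair: the fact that compounds 2 and 3 differ only in the configuration as drawn.

The compounds shown leave open how large the step really is, and whether the other stereo elements matter as much. They also leave open whether the same inversion would weaken a compound bearing an amine or a longer chain.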